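The source may hold more compounds than are shown below. What is called first, only, known or untested is meant among the compounds shown, and "the series" means these compounds.

Compound 1 `COc1cc2c(cc1OC)C(c1cccc([N+](=O)[O-])c1)=NNC(=O)C2`: > 120 umol/kg
Compound 2 `COc1cc2c(cc1OC)C(c1ccc(Cl)cc1)=NNC(=O)C2`: 102 umol/kg

Both compounds were tested in a functional assay on the whole organism with Mus musculus as the target; a lower number here means that less compound is needed, a higher number that more compound is needed for the effect. Compound 1 gives > 120 umol/kg, which is a limit of the assay and not a number. For the measured compounds named here, compound 2 gives 102 umol/kg, the only actual number so far, so it has no second number to be ranked against.

The next compound is compound 3 `COc1cc2c(cc1OC)C(c1cccc(N)c1)=NNC(=O)C2`, with 3-aminophenyl in place of 4-chlorophenyl on a carbon with a double bond to nitrogen. Going by the values given here, no step between measured compounds is available to size this exchange, so the expectation is loose: a moderate move towards less compound needed in this assay, possibly not beyond the scatter. The expected change is a 1.5-fold lower number from compound 2 to compound 3 (0.16 log units; within the scatter). Compound 3 is estimated at 70 umol/kg, with an expected range from 30 umol/kg to 150 umol/kg.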

Compound 3, dose for half-maximal effect: 19.3 umol/kg
Compound 3: the middle estimate sits 3.6-fold (0.56 log units) above what was measured, and the stated range ends above it.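

For the compounds shown here, the group on the carbon with a double bond to nitrogen clearly matters in this assay: 3-aminophenyl in place of 4-chlorophenyl gives a 5.3-fold lower number from compound 2 to compound 3 (0.72 log units; beyond the scatter), the first step here that can be sized. Amino in place of nitro on an aromatic carbon gives an at least 6.2-fold lower number from compound 1 to compound 3 (0.79 log units; beyond the scatter), so a change of that one group on the phenyl ring also reaches beyond the scatter. This second step is open-ended, as the value of compound 1 is a limit of the assay and not a number: the limit of > 120 umol/kg in this assay, at which 1 of the 3 values shown sits.

The step from 4-chlorophenyl to 3-aminophenyl changes both the group and its place on the phenyl ring, and the compounds shown do not separate the two; 4-aminophenyl or 3-chlorophenyl would do so. From the compounds shown here alone, it also remains open whether the free amine is needed, or whether a dimethylamino or acetamido group would serve as well.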